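From 4-chlorophenyl to phenyl: working notes

The source may report more compounds than this note shows. Statements on the series, on what has been measured and on what is new or still open speak of the compounds shown alone.

Measured in an ADME assay on HaCaT cells (Homo sapiens) for inhibition, read by sulforhodamine B assay, with a stated time of 48 h; on this read-out higher numbers stand for weaker inhibition of growth and lower numbers for stronger inhibition of growth:
- compound 1 `CCOC(=O)c1nn(-c2ccccc2)c(-c2ccccc2)c1CNC(C)(C)C`: 77000 nM; 13300 nM (2 entries)
- compound 2 `CC(C)(C)NCc1c(C(=O)O)nn(-c2ccccc2)c1-c1ccc(Cl)cc1`: > 652000 nM (a limit, not a number)

Compound 2 has no single number in this assay, and its further entry gives none either. Its standing rests on (the limit of > 652000 nM in this assay, at which 1 of the 2 values shown sits). Compound 1 gives 77000 nM; 13300 nM (2 entries), so its two entries differ from each other.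

Compound 3 `CC(C)(C)NCc1c(C(=O)O)nn(-c2ccccc2)c1-c1ccccc1` carries hydrogen in place of chloro on an aromatic carbon, para to a large group hydrogen in place of chloro on an aromatic carbon: 4-chlorophenyl to phenyl. Among the compounds with values here, no measured pair shows this change in this assay, and the size of any step from a limit stays open. No step beyond the scatter is expected, so the estimate starts from the limit of compound 2. The expected size of the change is a step that the limit leaves unreadable from compound 2 to compound 3. For compound 3 the estimated value is 700000 nM, with an expected range of 250000 nM to 1500000 nM.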

Compound 3, concentration for 50% growth inhibition: > 716000 nM
Compound 3 gave a limit, no number (the forecaster's own chance of this, stated with the estimate: 70%); at least 1.0-fold (0.00 log units) between middle value and limit.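

In this assay, compound 2 and compound 3 each give a limit, not a number, and no step can be read between them. The compounds shown leave open what 4-chlorophenyl to phenyl does to the read-out in this assay.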